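A few compounds are considered here, and "the series" means these few. Any claim that something is new, unique, unknown or untested is made for them only; others in the source may bear on it.

Compound 1 `N#Cc1c(NNC(N)=S)nc(SCc2nc3ccccc3[nH]2)nc1-c1ccccc1`: 3 nM
Compound 2 `N#Cc1c(NC(N)=S)nc(SCc2nc3ccccc3[nH]2)nc1-c1ccccc1`: 7.81 nM

In a functional assay on SK-OV-3 cells (Homo sapiens) for cytotoxicity, read by MTT assay, with a stated time of 3 days (a higher number here means a weaker inhibitor, a lower number a stronger inhibitor), compound 2 holds the higher of the two numbers at 7.81 nM, and compound 1 gives 3 nM. Compound 3 `N#Cc1c(NC(N)=O)nc(SCc2nc3ccccc3[nH]2)nc1-c1ccccc1` departs from compound 2 in one place: a group of 3 heavy atoms (1 carbon, 1 nitrogen, 1 oxygen; no ring) in place of a group of 3 heavy atoms (1 carbon, 1 nitrogen, 1 sulfur; no ring), on a nitrogen on an aromatic ring. Carbamoyl enters there, on a nitrogen on an aromatic ring. For the measured compounds named here, only one measured step bears on this, and only indirectly: a 2.6-fold higher number from compound 1 to compound 2 (0.42 log units; beyond the scatter), a modest change at the same nitrogen. Going by the values given here, no measured step exchanges sulfur for oxygen, so the direction has no direct support. A modest rise in the number, of similar size to that step, is tentatively expected in this assay. The estimated step is a 1.8-fold higher number from compound 2 to compound 3 (0.25 log units; within the scatter). Compound 3 is expected at 14 nM, with an estimated range of 4 nM to 45 nM.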

Compound 3, half-maximal inhibitory concentration: 6.75 nM
The estimate for compound 3 lay 2.1-fold (0.32 log units) above the measured number, within the range that was stated.
By their numbers in this assay, from the lowest: compound 1; then compounds 3 and 2 (each within the scatter of the next).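

In this assay, for the compounds shown here, exchanging sulfur for oxygen in the group on a nitrogen on an aromatic ring gives a 1.2-fold lower number from compound 2 to compound 3 (0.06 log units; within the scatter), so this exchange, which the earlier compounds did not cover, leaves the number within the scatter. The group of 4 heavy atoms now differs beyond the scatter from both groups of 3 heavy atoms, with a 2.6-fold higher number from compound 1 to compound 2 (0.42 log units; beyond the scatter) and a 2.3-fold higher number from compound 1 to compound 3 (0.35 log units; beyond the scatter), and among these three compounds the sulfur-bearing and oxygen-bearing groups of 3 heavy atoms stand on the same side of it. No evidence is available that would explain either observation.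

The compounds shown leave open whether the same exchange of sulfur for oxygen would be as quiet within the group of 4 heavy atoms. They also leave open what an acetyl group or a longer chain would give on this nitrogen in place of carbamoyl.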